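The source may report more compounds than this note shows. Statements on the series, on what has been measured and on what is new or still open speak of the compounds shown alone.

Compound 1 `COCC(COC)Nc1nc(C)nc2c1nnn2-c1ccc(C(C)C)cc1Br` and compound 2 `COCCCNc1nc(C)nc2c1nnn2-c1ccc(C(C)C)cc1Br` share one core and differ only in the group on the ring nitrogen. Among the measured compounds shown here, in an in vitro assay on 293-EBNA cells for binding affinity to corticotropin-releasing factor receptor 1 (Homo sapiens) (a lower number here means a stronger inhibitor, a higher number a weaker inhibitor), compound 1 gives 10.3 nM, while compound 2 gives 291 nM, the highest of the two numbers; the single measured step, a 28-fold higher number from compound 1 to compound 2 (1.45 log units; beyond the scatter), is large. Compound 3 `CCCCC(CCCC)Nc1nc(C)nc2c1nnn2-c1ccc(C(C)C)cc1Br` is not yet measured; it carries 1-butylpentyl in place of 3-methoxypropyl on a nitrogen on an aromatic ring. That earlier step bears on it only loosely, since it changed a different group. On that basis compound 3 is expected to sit at 25 nM, within 6 nM to 120 nM, an expected step of a 12-fold lower number from compound 2 to compound 3 (1.07 log units; beyond the scatter).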

Compound 3, inhibition constant: 4.5 nM
Compound 3: the middle estimate sits 5.6-fold (0.74 log units) above what was measured; measured number below the stated range.
By their numbers in this assay, from the lowest: compound 3; then compound 1; then compound 2.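

In this assay the step of a 65-fold lower number from compound 2 to compound 3 (1.81 log units; beyond the scatter) shows that this position on the nitrogen accepts 1-butylpentyl, a group with no oxygen and no hydrogen-bond acceptor. The step of a 2.3-fold lower number from compound 1 to compound 3 (0.36 log units; beyond the scatter) is modest but beyond the scatter, so the methoxy oxygens of compound 1 are not needed for a low number here. No evidence is available to explain these differences. The compounds shown leave open whether an unbranched nonyl chain would match 1-butylpentyl, and whether a branched group carrying an amine would be tolerated at this position.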